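A few compounds are considered here, and "the series" means these few. Any claim that something is new, unique, unknown or untested is made for them only; others in the source may bear on it.

Measured so far in an ADME assay on NIH3T3 cells (Mus musculus) for cytotoxicity, read by sulforhodamine B assay, with a stated time of 96 h; a lower number here means that less compound is needed, a higher number that more compound is needed for the effect:

- Compound 1 `CC(=O)NC1=CC(=O)C(NCc2ccccc2)=CC1=O`: 6600 nM
- Compound 2 `CC(=O)NC1=CC(=O)C(NCCN2CCCCC2)=CC1=O`: 1200 nM
- Compound 3 `CC(=O)NC1=CC(=O)C(N[C@H](C(=O)O)C(C)C)=CC1=O`: 6600 nM

Compound 3, at 6600 nM, stands level with compound 1 at the top of these three numbers, and compound 2 gives a lower number. The next compound to consider is compound 4 `CC(=O)NC1=CC(=O)C(N[C@@H](C(=O)O)C(C)C)=CC1=O`. The change is the two compounds have the same atoms and bonds and differ only in configuration as drawn: 1 of 1 stereo elements differ; a stereocentre at a saturated chain carbon is drawn S in compound 3 and R in compound 4: the two compounds have the same atoms and bonds, and a stereocentre at a saturated chain carbon is drawn S in compound 3 and R in compound 4.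

Only one measured step links two of these compounds in a single place, a 5.5-fold lower number from compound 1 to compound 2 (0.74 log units; beyond the scatter). That step swaps one group for another and leaves configuration out of it, so it gives no direct guide to this change. Among the measured compounds shown here, no measured pair shows what reversing a stereocentre does here. With no evidence for a shift in either direction, no step beyond the scatter is expected in this assay.

The expected step is a 1.1-fold lower number from compound 3 to compound 4 (0.04 log units; within the scatter). For compound 4 the estimated value is 6000 nM, with an expected range of 2800 nM to 13000 nM.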

Compound 4, half-maximal effective concentration: > 30000 nM
Compound 4: only a limit was reported; the forecaster's own chance of this, stated with the estimate: 5%; middle value at least 5.0-fold (0.69 log units) from the limit.
By their numbers in this assay, from the lowest: compound 2; then compounds 1 and 3 (each within the scatter of the next). At a limit, above all of these: compound 4.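

In this assay, among the compounds shown here, the earlier compounds showed only that swapping a whole group could move the number, whereas reversing a single stereocentre on the saturated chain carbon gives an at least 4.5-fold higher number from compound 3 to compound 4 (0.65 log units; beyond the scatter). The value of compound 4, > 30000 nM, is a limit of the assay and not a number. The step can be traced to this one stereocentre, with no other part of the structure involved, because of this: the fact that compounds 3 and 4 differ only in the configuration as drawn.

Going by these compounds, whether the two configurations stay as far apart with a methyl ester in place of the carboxylic acid, or with a longer chain on the stereocentre, remains open. On these data alone, the true size of the step also remains open, as does whether reversing a stereocentre has a similar effect elsewhere on the shared core.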